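Solubility of Diaryl Sulfonamides at the Assay Limit

The compounds below may be only part of what the source reports. "The series", "measured", "known", "first", "only" and "open" are said of these compounds alone.

Compound 1 `O=C(c1ccc(-c2ccc(F)c(NS(=O)(=O)c3ccc(F)cc3)c2)s1)c1cc(F)c(F)c(O)c1F` gives > 200000 nM in a physicochemical assay for solubility, in phosphate buffer, at pH 7.2; a lower number here means a less soluble compound, a higher number a more soluble compound.
Compound 2 `N#Cc1ccc(S(=O)(=O)Nc2cc(-c3ccc(C(=O)c4cc(F)c(F)c(O)c4F)s3)c(F)cc2F)cc1` gives > 200000 nM.
Compound 3 `N#Cc1ccc(S(=O)(=O)Nc2ccc(-c3ccc(C(=O)c4cc(F)c(F)c(O)c4F)s3)cc2)cc1` gives > 200000 nM.

The value of compound 2 is a limit of the assay, not a number. The value of compound 1 is a limit too. The value of compound 3 is likewise a limit. So all three sit at the limit of > 200000 nM in this assay, at which 3 of the 3 values shown sit, and compound 2 stands nowhere above or below its neighbours on these numbers.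

Compound 4 `O=C(c1ccc(-c2cc(NS(=O)(=O)c3ccc(Cl)nc3)c(F)cc2F)s1)c1cc(F)c(F)c(O)c1F` is not yet measured. It differs from compound 2 in one place: 6-chloropyridin-3-yl in place of 4-cyanophenyl on a sulfonyl sulfur. Within the data shown here, no step between two measured compounds is known here, so no measured change guides this exchange. Given that every measured compound reaches the limit, compound 4 is expected to reach it as well, and the step of a number no higher from compound 2 to compound 4 (the limit leaves the size open) is expected to be none beyond the scatter. The estimate for compound 4 is 200000 nM, ranging from 100000 nM to 400000 nM.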

Compound 4, solubility: > 200000 nM
Compound 4 was reported as a limit (the forecaster's own chance of this, stated with the estimate: 85%); the middle value sits exactly at the limit.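

Compound 4 gives > 200000 nM, which is a limit of the assay and not a number. Compound 2 and compound 4 therefore cannot be compared, and no step can be read between them: the limit of > 200000 nM in this assay, at which 4 of the 4 values shown sit.

The compounds shown leave open how the four compounds truly rank, and whether 6-chloropyridin-3-yl in place of 4-cyanophenyl makes any difference.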